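Hydroxyphenyl in Place of Iodophenyl: Dose Still Expected High

The source may report more compounds than this note shows. Statements on the series, on what has been measured and on what is new or still open speak of the compounds shown alone.

Measured so far:
compound 1 `CC1CC/C(=N\Nc2ccc(F)cc2)c2ncc(C(=O)O)c(=O)n21` — > 1000 umol/kg
compound 2 `CC1CC/C(=N\Nc2ccccc2Br)c2ncc(C(=O)O)c(=O)n21` — > 320 umol/kg
compound 3 `CC1CC/C(=N\Nc2ccc(I)cc2)c2ncc(C(=O)O)c(=O)n21` — > 1000 umol/kg

All three compounds share one core and differ only in the aryl group on the amine nitrogen. They were tested in a functional assay on the whole organism for inhibition, with Rattus norvegicus as the target; a higher number here means that more compound is needed for the effect, a lower number that less compound is needed. Compound 1 gives > 1000 umol/kg, which is a limit of the assay and not a number. Compound 2 gives > 320 umol/kg, also a limit. Compound 3 gives > 1000 umol/kg, again a limit. Every value is a limit. The steps between them cannot be sized: a step that the two limits leave unreadable from compound 1 to compound 2, a step that the two limits leave unreadable from compound 1 to compound 3 and a step that the two limits leave unreadable from compound 2 to compound 3. Two of the three values sit at the limit of > 1000 umol/kg in this assay, at which 2 of the 3 values shown sit, and one sits at the limit of > 320 umol/kg in this assay, at which 1 of the 3 values shown sits. Compound 3 therefore stands at the higher of the two limits, with no measured number to place it more exactly.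

Compound 4 `CC1CC/C(=N\Nc2ccccc2O)c2ncc(C(=O)O)c(=O)n21` is the next analogue. Its change from compound 3 is 2-hydroxyphenyl in place of 4-iodophenyl on an amine nitrogen. For the measured compounds named here, no measured step here has a readable size, so none gives a direction for this change. The step of a number no higher from compound 3 to compound 4 (the limit leaves the size open) is expected to stay within the scatter, with compound 4 most likely again reported only as a limit. The estimate for compound 4 is 1000 umol/kg, with a range from 300 umol/kg to 3000 umol/kg.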

Compound 4, dose for 50% inhibition: > 100 umol/kg
Compound 4 ended at the assay's limit; the forecaster's own chance of this, stated with the estimate: 70%; the middle value lies beyond the limit too.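

In this assay compound 4 gives > 100 umol/kg, a limit of the assay and not a number. For the compounds shown here, compound 1, compound 2 and compound 3 are also reported only as limits, so no step to compound 4 can be read. The compounds shown leave open what dose any of these aryl groups actually requires, and whether changing that group alters the dose at all.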